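Removing the pyridyl amide arm: permeability of compound 4

This account rests on a few compounds, and the source may have more. Where it says the series, first, only, none or still open, it means among the compounds named here.

Measured compounds in an ADME assay for permeability, using PAMPA, at pH 5.5; on this read-out higher numbers stand for higher permeability and lower numbers for lower permeability:
- compound 1 `CCCCc1nc(=O)c(S(=O)(=O)c2ccc(-c3ccnc(NC(=O)C4CC4)c3)cc2)c(O)n1-c1c(OC)cccc1OC`: 183 nm/s
- compound 2 `CCCCc1[nH]c(=O)c(S(=O)(=O)c2ccc(-c3cccnc3OC)cc2)c(O)c1-c1c(OC)cccc1OC`: "not determined" (no result reported)
- compound 3 `COc1cccc(OC)c1-n1c(COC(C)C)nc(=O)c(S(=O)(=O)c2ccc(-c3ccc(F)nc3)cc2)c1O`: 75 nm/s

Among the two compounds with a number in this assay, compound 1 stands highest with 183 nm/s, while compound 3 gives the lower value of 75 nm/s, a gap beyond the usual scatter. For compound 2 no result was reported.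

Compound 4 `CCCCc1nc(=O)c(S(=O)(=O)c2ccccc2)c(O)n1-c1c(OC)cccc1OC` is not yet measured. It differs from compound 1 in one place: hydrogen in place of 2-((cyclopropylcarbonyl)amino)pyridin-4-yl on an aromatic carbon. Compound 1 thus loses its largest peripheral substituent and keeps the shared core otherwise unchanged.

For the measured compounds named here, no measured pair in this set shows this kind of change, so its effect is not known from the data. Compound 4 is expected to give a value close to or somewhat above that of compound 1 in this assay, with the step of a 1.5-fold higher number from compound 1 to compound 4 (0.18 log units; within the scatter) expected to be small, at the edge of the scatter. The estimate for compound 4 is 280 nm/s, within a range of 110 nm/s to 700 nm/s.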

Compound 4, apparent permeability: 141 nm/s
For compound 4 the middle estimate is 2.0-fold (0.30 log units) above the measured one, within the range that was stated.
By their numbers in this assay, from the lowest: compounds 3, 4 and 1 (each within the scatter of the next, the first and the last beyond it).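

In this assay, for the compounds shown here, this is the first pair differing in one place, and hydrogen in place of 2-((cyclopropylcarbonyl)amino)pyridin-4-yl on an aromatic carbon of a six-membered aromatic ring of carbon only gives a 1.3-fold lower number from compound 1 to compound 4 (0.11 log units; within the scatter). The read-out therefore does not separate the two compounds, even though the change removes a group of 12 heavy atoms, including a three-membered ring of carbon and a six-membered aromatic ring with 1 hetero atom. Nothing in the available data accounts for this result.

The compounds shown leave open whether an amine or a carboxylic acid at this position would also stay within the scatter of compound 1. As far as these compounds go, it also remains open whether a plain pyridine ring without the cyclopropylcarbonyl amide would do so, and whether hydrogen at this position would read the same on the shared core of compound 3.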